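The source may report more compounds than this note shows. Statements on the series, on what has been measured and on what is new or still open speak of the compounds shown alone.

Three compounds built on one shared core have been run in an ADME assay (liver) for metabolic stability, with Liver microsome (Homo sapiens) as the target, using microsomes, tested at 1 uM; a higher number here means faster removal of the compound, a lower number slower removal. Compound 2 `COc1ccc2c(c1O)CCCC=C2c1cc(OC)c(OC)c(OC)c1` gives 54.1 mL.min-1.g-1. Compound 3 `COc1ccc2c(c1O)CCCC(C)=C2c1cc(OC)c(OC)c(OC)c1` gives 108 mL.min-1.g-1, the highest of the two numbers, although compound 2 lies a 2.0-fold higher number from compound 2 to compound 3 (0.30 log units; within the scatter). For compound 1 `COc1ccc2c(c1O)CCCC(CCC#N)=C2c1cc(OC)c(OC)c(OC)c1` this assay reports only a limit, > 320 mL.min-1.g-1. Compound 4 `COc1ccc2c(c1O)CCCC(Cc1ccccc1)=C2c1cc(OC)c(OC)c(OC)c1` has not yet been measured; it differs from compound 3 by phenyl in place of hydrogen on a saturated chain carbon bound to a double-bonded ring carbon. For the measured compounds named here, two measured steps bear on this change: a 2.0-fold higher number from compound 2 to compound 3 (0.30 log units; within the scatter), and an at least 2.9-fold lower number from compound 1 to compound 3 (0.47 log units; beyond the scatter), where a group was removed from that same saturated chain carbon. Compound 1, carrying a group there, sits at the limit of > 320 mL.min-1.g-1 in this assay, at which 1 of the 3 values shown sits. A larger group entering in compound 4 is therefore expected to raise the number, by a 2.3-fold higher number from compound 3 to compound 4 (0.36 log units; beyond the scatter). Compound 4 is estimated at 250 mL.min-1.g-1, between 110 mL.min-1.g-1 and 550 mL.min-1.g-1.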

Compound 4, intrinsic clearance in microsomes: 51.2 mL.min-1.g-1
For compound 4 the middle estimate is 4.9-fold (0.69 log units) above the measured one; the measured number lies below the stated range.
By their numbers in this assay, from the lowest: compounds 4, 2 and 3 (each within the scatter of the next, the first and the last beyond it). At a limit, above all of these: compound 1.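

In this assay, phenyl on the saturated chain carbon bound to a double-bonded ring carbon gives a 2.1-fold lower number from compound 3 to compound 4 (0.32 log units; beyond the scatter), so among these compounds the number does not follow the size of the group at this position. Benzyl in place of hydrogen gives a 1.1-fold lower number from compound 2 to compound 4 (0.02 log units; within the scatter), which leaves the two compounds within the scatter of each other. The step of an at least 6.2-fold lower number from compound 1 to compound 4 (0.79 log units; beyond the scatter) rests on a limit of the assay: the limit of > 320 mL.min-1.g-1 in this assay, at which 1 of the 4 values shown sits.

On these data alone, whether a phenyl carrying an amine or a carboxylic acid would behave like the plain phenyl stays open. So does the effect of a longer chain ending in phenyl.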